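Methylating the sulfanyl group of compound 3

This account rests on a few compounds, and the source may have more. Where it says the series, first, only, none or still open, it means among the compounds named here.

Measured in a functional assay on MT4 cells (Homo sapiens) for inhibition; a lower number here means a stronger inhibitor, a higher number a weaker inhibitor:
- compound 1 `C=C1[C@H](n2cnc3c(Cl)nc(N)nc32)O[C@H](CO)[C@H]1O`: 176000 nM
- compound 2 `C=C1[C@H](n2cnc3c(OC)nc(N)nc32)O[C@H](CO)[C@H]1O`: 180000 nM
- compound 3 `C=C1[C@H](n2cnc3c(S)nc(N)nc32)O[C@H](CO)[C@H]1O`: 480 nM

In this assay compound 3 has the lowest number of the three, and its steps to both others lie beyond the scatter. The next change gives compound 4 `C=C1[C@H](n2cnc3c(SC)nc(N)nc32)O[C@H](CO)[C@H]1O`: methyl in place of hydrogen on a sulfur. This places methyl in place of hydrogen on a sulfur. Among the compounds with values here, the steps that bear on it are a 370-fold lower number from compound 1 to compound 3 (2.56 log units; beyond the scatter) and a 380-fold lower number from compound 2 to compound 3 (2.57 log units; beyond the scatter), both large, whereas a 1.0-fold higher number from compound 1 to compound 2 (0.01 log units; within the scatter) lies within the scatter. Among these three, only compound 3 holds a sulfanyl hydrogen, and compound 4 loses that hydrogen while keeping the sulfur. Within the data shown here, no measured step tests a change on the sulfur itself, so the range stays wide. A large step to a higher number is expected: a 130-fold higher number from compound 3 to compound 4 (2.10 log units; beyond the scatter). For compound 4 the estimated value is 60000 nM, with an expected range of 8000 nM to 250000 nM.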

Compound 4, half-maximal inhibitory concentration: > 500000 nM
Compound 4: only a limit was reported; the forecaster's own chance of this, stated with the estimate: 20%; middle value at least 8.3-fold (0.92 log units) away from the limit.
By their numbers in this assay, from the lowest: compound 3; then compounds 1 and 2 (each within the scatter of the next). At a limit, above all of these: compound 4.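

In this assay, compound 4 is reported only as a limit: the limit of > 500000 nM in this assay, at which 1 of the 4 values shown sits.

The sulfur alone therefore does not give the low number of compound 3, as putting methyl in place of the hydrogen on that sulfur gives an at least 1000-fold higher number from compound 3 to compound 4 (3.01 log units; beyond the scatter). Methylsulfanyl also offers no match for the other two groups on the aromatic carbon, with an at least 2.7-fold higher number from compound 2 to compound 4 (0.44 log units; beyond the scatter) and an at least 2.8-fold higher number from compound 1 to compound 4 (0.45 log units; beyond the scatter), so the low number in this set belongs to sulfanyl alone and not to sulfur-linked groups in general.

On these data alone, whether an amine or a hydroxyl on the same aromatic carbon could give a comparably low number remains open. As far as these compounds go, the limit also leaves the true size of all three steps unresolved, and how a longer chain on the sulfur, such as ethyl, would compare with methyl is unknown.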